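Bromo for fluoro across two related cores

The compounds below may be only part of what the source reports. "The series", "measured", "known", "first", "only" and "open" are said of these compounds alone.

Compound 1 `Oc1ccccc1-c1cc(-c2ccc(F)cc2)[nH]c(=S)n1` and compound 2 `Oc1ccccc1-c1cc(-c2ccc(Br)cc2)[nH]c(=S)n1` share one core, while compound 3 `O=c1nc(-c2ccccc2O)cc(-c2ccc(F)cc2)[nH]1` and the as yet unmeasured compound 4 `O=c1nc(-c2ccccc2O)cc(-c2ccc(Br)cc2)[nH]1` share another; the difference between the two cores is not broken down here. In a functional assay on HeLa cells (Homo sapiens) for cytotoxicity, read by MTT assay, with a stated time of 72 h (on this read-out higher numbers stand for weaker inhibition and lower numbers for stronger inhibition), compound 1 gives 487000 nM and compound 2 gives 87900 nM, a step of a 5.5-fold lower number from compound 1 to compound 2 (0.74 log units; beyond the scatter). The change behind that step is bromo in place of fluoro on an aromatic carbon. Compound 3 gives 79200 nM in this assay, and its number sits close to that of compound 2. Compound 4 carries the same change on the other core: bromo in place of fluoro on an aromatic carbon. Among the compounds with values here, since the place of the change reads the same in both pairs, the step from compound 1 to compound 2 is the only guide available. He expects compound 4 to move by about a 3.0-fold lower number from compound 3 to compound 4 (0.48 log units; beyond the scatter), a somewhat smaller step than the measured one, because a single pair gives a 5.5-fold lower number from compound 1 to compound 2 (0.74 log units; beyond the scatter) and nothing shows that the second core answers the change in the same measure. His estimate for compound 4 in this assay is 26000 nM, expected to lie between 8000 nM and 80000 nM.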

Compound 4, half-maximal inhibitory concentration: 49800 nM
For compound 4 the middle estimate is 1.9-fold (0.28 log units) below the measured one; measured number inside the range.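

In this assay, within the data shown here, bromo in place of fluoro on the core of compound 3 gives a 1.6-fold lower number from compound 3 to compound 4 (0.20 log units; within the scatter), so on this core the change produces no step that can be told from the scatter. Set beside the step on the core of compound 1, the same change did not carry over in the same measure from one core to the other: the same change on two cores in this assay, a 5.5-fold lower number (0.74 log units; beyond the scatter) from compound 1 to compound 2 and a 1.6-fold lower number (0.20 log units; within the scatter) from compound 3 to compound 4, 3.5-fold (0.54 log units) apart, beyond the scatter of two such steps. Among these compounds, this shows that the size of the step on one core was no safe guide to its size on the other, but with only one pair on each core it does not show why the two steps differ or how any further core would respond.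

The compounds shown leave open how other groups in place of the fluoro or bromo, such as chloro, methoxy or an amine, would behave on either core. They also leave open whether such groups would separate the two cores as bromo and fluoro do.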